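A few compounds are considered here, and "the series" means these few. Any claim that something is new, unique, unknown or untested is made for them only; others in the source may bear on it.

Of the compounds shown here, three have so far been tested in a functional assay on colon cells (Homo sapiens) for antiproliferative activity; on this read-out lower numbers stand for stronger inhibition of growth and higher numbers for weaker inhibition of growth. Compound 1 (`Cc1sc2nc(-c3ccncc3)c(/C=N/NC(=N)N)n2c1C`) gives 35500 nM, compound 2 (`Cc1cn2c(/C=N/NC(=N)N)c(-c3cccnc3)nc2s1`) gives 5620 nM, and compound 3 (`N=C(N)N/N=C/c1c(-c2ccccn2)nc2sc(Cl)cn12`) gives 7080 nM. Compound 3 thus lies within the scatter of compound 2, while compound 1 stands beyond the scatter above compound 3.

The next compound, compound 4 (`N=C(N)N/N=C/c1c(-c2ccncc2)nc2sc(Cl)cn12`), has the same atoms as compound 3, joined differently: pyridin-4-yl in place of pyridin-2-yl on an aromatic carbon, (pyridin-4-yl in place of pyridin-2-yl on an aromatic carbon). Going by the values given here, no measured pair isolates this exchange. Among the compounds with values here, the only guide is compound 1, which also carries pyridin-4-yl and gives 35500 nM, but the rest of compound 1 differs from compound 4 as well, so it offers only a weak hint toward a higher number.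

A modest rise in this assay is therefore expected, with the estimated step of a 1.4-fold higher number from compound 3 to compound 4 (0.15 log units; within the scatter) lying close to the scatter. For compound 4 the estimate is 10000 nM, with an expected range of 3500 nM to 28000 nM.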

Compound 4, concentration for 50% growth inhibition: 8130 nM
Estimate against measurement, compound 4: 1.2-fold (0.09 log units) above, and the stated range covers the measured number.
By their numbers in this assay, from the lowest: compounds 2, 3 and 4 (each within the scatter of the next); then compound 1.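

In this assay, going by these compounds alone, pyridin-4-yl in place of pyridin-2-yl on this aromatic carbon gives a 1.1-fold higher number from compound 3 to compound 4 (0.06 log units; within the scatter), and this pair is the first to isolate a change at this position. With the rest of the molecule held constant, the two pyridine attachments cannot be told apart at this position on this core, so the exchange alone leaves the growth-inhibition read-out within the scatter. Nothing available on these compounds accounts for this outcome.

Going by these compounds, both groups compared are pyridine rings with the same counts of atoms, so it remains open how the position responds to a different kind of group, such as phenyl, morpholine or a simple amine. On these data alone, it also remains open whether the same exchange would read alike on a core carrying methyl in place of chlorine.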